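Swapping the chlorophenoxy arm for a benzoxazolylsulfanyl arm

The source may hold more compounds than are shown below. What is called first, only, known or untested is meant among the compounds shown, and "the series" means these compounds.

Compound 1 `COc1ccc(CN(C(=O)COc2ccc(OC)cc2)c2cc(OC)c(OC)c(OC)c2)cc1`: 6270 nM
Compound 2 `COc1ccc(CN(C(=O)CSc2ccccn2)c2cc(OC)c(OC)c(OC)c2)cc1`: 2410 nM
Compound 3 `COc1ccc(CN(C(=O)COc2cccc(Cl)c2)c2cc(OC)c(OC)c(OC)c2)cc1`: 68700 nM

All three compounds share one core and differ only in the group sitting on a saturated chain carbon bound to a carbonyl carbon. In a functional assay on MGC-803 cells (Homo sapiens) for antiproliferative activity, read by MTT assay, with a stated time of 48 h (on this read-out lower numbers stand for stronger inhibition and higher numbers for weaker inhibition), compound 3 gives the highest number of the three, meaning the weakest inhibition: an 11-fold higher number from compound 1 to compound 3 (1.04 log units; beyond the scatter) and a 29-fold higher number from compound 2 to compound 3 (1.45 log units; beyond the scatter) both describe steps that are large and well beyond the scatter.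

Compound 4 `COc1ccc(CN(C(=O)CSc2nc3ccccc3o2)c2cc(OC)c(OC)c(OC)c2)cc1` arises from compound 3 by a single change: (1,3-benzoxazol-2-yl)sulfanyl in place of 3-chlorophenoxy on a saturated chain carbon bound to a carbonyl carbon. The closest guide is the step in which a sulfur-linked aromatic heterocycle was exchanged for the chlorophenoxy group, a 29-fold higher number from compound 2 to compound 3 (1.45 log units; beyond the scatter), a large rise in the number. Read in reverse, putting a sulfur-linked aromatic heterocycle back in place of the chlorophenoxy group would be expected to bring the number down sharply. A second hint is a 2.6-fold lower number from compound 1 to compound 2 (0.42 log units; beyond the scatter), a modest drop when a sulfur-linked heterocycle replaced an oxygen-linked aromatic ring. On this basis compound 4 is expected to show a 17-fold lower number from compound 3 to compound 4 (1.23 log units; beyond the scatter) in this assay. Compound 4 is therefore estimated at 4000 nM, with a likely range from 1000 nM to 20000 nM.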

Compound 4, half-maximal inhibitory concentration: 450 nM
Compound 4: the middle estimate sits 8.9-fold (0.95 log units) above what was measured; the measured number lies below the stated range.
By their numbers in this assay, from the lowest: compound 4; then compound 2; then compound 1; then compound 3.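

In this assay, for the compounds shown here, this position tolerates far more than the earlier compounds showed: a 150-fold lower number from compound 3 to compound 4 (2.18 log units; beyond the scatter) is the largest step in the set, and it ends at the lowest number of the four, with the steps to all three others printed as beyond the scatter. The sulfur-linked compounds also show something new, as a 5.4-fold lower number from compound 2 to compound 4 (0.73 log units; beyond the scatter) keeps the sulfur on the saturated chain carbon bound to a carbonyl carbon and changes only the ring attached to it, so the sulfur link alone does not set the number and the identity of the ring matters too. Against the better of the two oxygen-linked arms, a 14-fold lower number from compound 1 to compound 4 (1.14 log units; beyond the scatter) is also a large step, so the gain from 1,3-benzoxazol-2-yl is not limited to a comparison with the weak 3-chlorophenoxy arm.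

These compounds leave open whether the 1,3-benzoxazol-2-yl ring needs its sulfur, since here it appears only on sulfur, and how an amine such as piperidine or a carboxylic acid would behave at this place. Nothing given here offers an explanation for the size of these steps.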